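The source may report more compounds than this note shows. Statements on the series, on what has been measured and on what is new or still open speak of the compounds shown alone.

Compound 1 `COc1ccc(/C=C/c2cc(OC)cc(OC)c2/C=C/C(=O)NC2CC2)cc1`: 10200 nM
Compound 2 `COc1ccc(/C=C/c2cc(OC)cc(OC)c2/C=C/C(=O)N(CC(C)C)CC(C)C)cc1`: 4850 nM
Compound 3 `CCCCCN(CCCCC)C(=O)/C=C/c1c(/C=C/c2ccc(OC)cc2)cc(OC)cc1OC`: 9270 nM

In a functional assay on B16-F10 cells (Mus musculus) for inhibition, read by MTT assay, with a stated time of 48 h (a higher number here means a weaker inhibitor, a lower number a stronger inhibitor), compound 3 gives the second highest of the three numbers, and it sits close to both neighbours: the step of a 1.1-fold lower number from compound 1 to compound 3 (0.04 log units; within the scatter) and the step of a 1.9-fold higher number from compound 2 to compound 3 (0.28 log units; within the scatter) both lie within the scatter. Compound 4 `COc1ccc(/C=C/c2cc(OC)cc(OC)c2/C=C/C(=O)N2CCCC(C)C2)cc1` is the next compound, differing from compound 3 only at the amide nitrogen: 3-methylpiperidin-1-yl in place of dipentylamino on a carbonyl carbon.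

All three measured steps swap groups on this same carbonyl carbon. Only one of them, a 2.1-fold lower number from compound 1 to compound 2 (0.32 log units; beyond the scatter), is beyond the scatter, and even that is modest; the other two are within it. A change of this kind is therefore expected to move the number little, in no clear direction. Compound 4 is expected to give 7000 nM, within 3500 nM to 14000 nM, which is the estimated step of a 1.3-fold lower number from compound 3 to compound 4 (0.12 log units; within the scatter).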

Compound 4, half-maximal inhibitory concentration: 8250 nM
For compound 4 the middle estimate is 1.2-fold (0.07 log units) below the measured one, within the range that was stated.
By their numbers in this assay, from the lowest: compounds 2, 4, 3 and 1 (each within the scatter of the next, the first and the last beyond it).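

In this assay, a six-membered non-aromatic ring on the carbonyl carbon, 3-methylpiperidin-1-yl, replaces the open-chain dipentylamino with fewer heavy atoms, and the step is small: a 1.1-fold lower number from compound 3 to compound 4 (0.05 log units; within the scatter). The other two comparisons, a 1.7-fold higher number from compound 2 to compound 4 (0.23 log units; within the scatter) and a 1.2-fold lower number from compound 1 to compound 4 (0.09 log units; within the scatter), also lie within the scatter, so this ring fits among the earlier groups without separating from any of them. No available data explain this result. As far as these compounds go, whether a ring carrying a second hetero atom, such as morpholine, or an added carboxylic acid would shift the number remains open.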